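The source may hold more compounds than are shown below. What is called first, only, known or untested is meant among the compounds shown, and "the series" means these compounds.

Of the compounds shown here, two measured so far share one core and differ only in the chain attached to the aromatic nitrogen. Compound 1 `CCCCn1ccc(N2CCC(c3ccccc3)CC2)c(C#N)c1=O` gives 95 nM in a functional assay on CHO cells for positive allosteric modulation of metabotropic glutamate receptor 2 (Homo sapiens), with a stated time of 30 min; a higher number here means that more compound is needed for the effect, a lower number that less compound is needed. Compound 2 `N#Cc1c(N2CCC(c3ccccc3)CC2)ccn(CC2CC2)c1=O` gives 151 nM in this assay. Among the compounds with values here, the only step between them, a 1.6-fold higher number from compound 1 to compound 2 (0.20 log units; within the scatter), exchanges one small saturated chain for another and stays within the scatter. Among the two measured compounds, compound 2 sits at one end of the range, but the single step to it, from compound 1, lies within the scatter, so the two numbers cannot be told apart.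

Compound 3 `COc1ccccc1C1CCN(c2ccn(CC3CC3)c(=O)c2C#N)CC1` keeps the cyclopropyl chain of compound 2 and differs in one place: methoxy in place of hydrogen on an aromatic carbon. Within the data shown here, none of the measured steps touches the phenyl ring, so nothing measured here shows how a methoxy group at that place changes the number. Among the measured compounds shown here, with no step to lean on, the change a 1.0-fold lower number from compound 2 to compound 3 (0.00 log units; within the scatter) is expected to stay within the scatter, in no particular direction. Compound 3 is therefore estimated at 150 nM, with a range from 50 nM to 450 nM.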

Compound 3, half-maximal effective concentration: 35 nM
The estimate for compound 3 lay 4.3-fold (0.63 log units) above the measured number; measured number below the stated range.
By their numbers in this assay, from the lowest: compound 3; then compounds 1 and 2 (each within the scatter of the next).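

In this assay, methoxy in place of hydrogen, on an aromatic carbon ortho to a large group, gives a 4.3-fold lower number from compound 2 to compound 3 (0.63 log units; beyond the scatter) and so turns phenyl into 2-methoxyphenyl. This is the first step among these compounds that lies beyond the scatter, and it gives the first measured sign that the number responds to a change on this ring, although the step is modest and rests on a single pair of compounds. The earlier step, a 1.6-fold higher number from compound 1 to compound 2 (0.20 log units; within the scatter), changed the chain on the aromatic nitrogen and could not be told from the scatter, and nothing at hand explains why the methoxy step lowers the number.

The compounds shown leave open whether other groups on the same carbon, such as ethoxy, hydroxy or a chlorine atom, would lower the number as well, or whether only methoxy does so. They also leave open whether methoxy on another carbon of this ring would have a similar effect, and whether the same change would give a similar step when paired with the chain of compound 1.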